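The compounds below may be only part of what the source reports. "The series", "measured", "known", "first", "only" and "open" are said of these compounds alone.

In a functional assay on HEK293 cells (Homo sapiens) for cytotoxicity (on this read-out lower numbers stand for higher toxicity in this test and higher numbers for lower toxicity in this test), compound 1 (`COc1ccc([C@H]2CC(=O)N(c3ccccc3)C2)cc1OC1CCCC1`) gives > 10000 nM as a limit, not a number. Compound 2 (`COc1ccc([C@H]2CC(=O)N(c3cccc(C)c3)C2)cc1OC1CCCC1`) gives > 10000 nM as a limit too. Compound 3 (`COc1ccc([C@H]2CC(=O)N(c3cccc(C(F)(F)F)c3)C2)cc1OC1CCCC1`) stands at > 10000 nM as a limit also, so its place is known only as a bound. Among the compounds with values here, the series so far offers the limit of > 10000 nM in this assay, at which 3 of the 3 values shown sit, and nothing finer. Compound 4 (`COc1ccc([C@H]2CC(=O)N(c3cccc(NCC4CCOC4)c3)C2)cc1OC1CCCC1`) carries ((oxolan-3-yl)methyl)amino in place of trifluoromethyl on an aromatic carbon on the same core. Bearing on this change are a step that the two limits leave unreadable from compound 1 to compound 3 and also a step that the two limits leave unreadable from compound 2 to compound 3 but neither has a size to carry over. In this assay no clear move is therefore expected, and the expected change is a step that the limit leaves unreadable from compound 3 to compound 4 with no firm direction. For compound 4 the estimate is 15000 nM with 6000 nM to 40000 nM as its expected range.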

Compound 4, half-maximal cytotoxic concentration: > 10000 nM
Compound 4: only a limit was reported; the forecaster's own chance of this, stated with the estimate: 80%; the middle value does not contradict the limit.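

In this assay, within the data shown here, compound 4 also gives only a limit, so no step from compound 1, compound 2 or compound 3 to compound 4 can be read: the limit of > 10000 nM in this assay, at which 4 of the 4 values shown sit. The compounds shown leave open whether any of these groups on the shared core changes the half-maximal cytotoxic concentration at all.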